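A few compounds are considered here, and "the series" means these few. Any claim that something is new, unique, unknown or untested is made for them only; others in the source may bear on it.

Measured compounds and their results in a functional assay on MCF7 cells (Homo sapiens) for antiproliferative activity, read by MTT assay, with a stated time of 72 h; on this read-out lower numbers stand for stronger inhibition and higher numbers for weaker inhibition:
Compound 1, `CCN(CC)CCCNC(=O)c1ccc(C(CC)(CC)c2ccc(C#CC(O)(CC)CC)c(C)c2)n1CC`, gives 17800 nM.
Compound 2, `C#CCCOC(=O)c1ccc(C(CC)(CC)c2ccc(C#CC(O)(CC)CC)c(C)c2)n1CC`, reaches only the assay limit of > 50000 nM.
Compound 3, `CCn1cc(C(CC)(CC)c2ccc(C#CC(O)(CC)CC)c(C)c2)cc1C(=O)NCC(=O)OC`, gives 26500 nM.

Of the two plain numbers, compound 3 holds the higher one, yet its gap to compound 1 lies within the scatter, so no order between the two can be read. Compound 4, `CCn1cc(C(CC)(CC)c2ccc(C#CC(O)(CC)CC)c(C)c2)cc1C(=O)N[C@@H](C)CO`, is the compound still to be measured. It differs from compound 3 in one place: 1-(hydroxymethyl)ethyl in place of (methoxycarbonyl)methyl on an amide-type nitrogen.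

Going by the values given here, only one measured step exists, an at least 2.8-fold higher number from compound 1 to compound 2 (0.44 log units; beyond the scatter), and it alters the group on the carbonyl carbon rather than on the amide-type nitrogen, so it does not bear directly on the present change. One of the three values sits at the limit of > 50000 nM in this assay, at which 1 of the 3 values shown sits. Among the compounds with values here, no measured step exchanges the substituent on an amide-type nitrogen. Compound 1 and compound 3 carry different groups on that nitrogen and show values within the scatter of each other, which is the only hint available.

The step from compound 3 to compound 4 is therefore expected to be a 1.1-fold lower number from compound 3 to compound 4 (0.03 log units; within the scatter), nothing beyond the scatter. Compound 4 is estimated at 25000 nM, with a range from 10000 nM to 60000 nM.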

Compound 4, half-maximal inhibitory concentration: 1910 nM
The estimate for compound 4 lay 13-fold (1.12 log units) above the measured number, and the stated range ends above it.
By their numbers in this assay, from the lowest: compound 4; then compounds 1 and 3 (each within the scatter of the next). At a limit, above all of these: compound 2.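

In this assay, going by these compounds alone, the substituent on the amide-type nitrogen turns out to matter a great deal: 1-(hydroxymethyl)ethyl in place of (methoxycarbonyl)methyl gives a 14-fold lower number from compound 3 to compound 4 (1.14 log units; beyond the scatter), the first measured change at this position and a large one. The exchange alters several things at once, since the group that leaves has a double bond outside aromatic rings and no hydrogen-bond donor, while the group that enters has a hydrogen-bond donor and a defined stereocentre, and this single step cannot separate these differences from one another. Nothing measured here gives a cause for the size of this step.

The compounds shown leave open which of these differences carries the step, and whether the opposite configuration at the stereocentre, or a plain 2-hydroxyethyl group without the methyl branch, would give a similar number. They also leave open how far the position tolerates other groups on that nitrogen, such as a carboxylic acid in place of the methyl ester, an amine, or a longer hydroxyalkyl chain.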